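A few compounds are considered here, and "the series" means these few. Any claim that something is new, unique, unknown or untested is made for them only; others in the source may bear on it.

Working notes on the series. Compound 1 `CC(=O)N1CCN(c2ccc(Nc3ncc(C(F)(F)F)c(N4Cc5cccc(N(C)S(C)(=O)=O)c5C4)n3)cc2)CC1` and compound 2 `Cc1ccc(Nc2ncc(C(F)(F)F)c(N3Cc4cccc(N(C)S(C)(=O)=O)c4C3)n2)c(Cl)c1` share the same core and differ only in the aryl group carried on the amino nitrogen. In a functional assay on OVCAR-3 cells (Homo sapiens) for antiproliferative activity, read by spectrophotometry, with a stated time of 2 days (on this read-out lower numbers stand for stronger inhibition of growth and higher numbers for weaker inhibition of growth), compound 1 gives 970 nM. Compound 2 in this assay returns only a limit of the assay, > 30000 nM, so no number stands for it. Compound 2 therefore sits at the weak end of the two results shown, as the limit of > 30000 nM in this assay, at which 1 of the 2 values shown sits, makes clear. Compound 3 `CN(c1cccc2c1CN(c1nc(Nc3ccc(Cl)c(C(F)(F)F)c3)ncc1C(F)(F)F)C2)S(C)(=O)=O` has not yet been measured. It differs from compound 2 in one place: 4-chloro-3-(trifluoromethyl)phenyl in place of 2-chloro-4-methylphenyl on a nitrogen on an aromatic ring. Going by the values given here, no pair of measured compounds differs in just this way, so the size of the step cannot be read off from the data. Given that compound 2 reaches only the limit, the step from compound 2 to compound 3 in this assay is expected to run toward stronger inhibition of growth, by an at least 5.0-fold lower number from compound 2 to compound 3 (0.69 log units; beyond the scatter), though the chance that compound 3 also ends at the limit stays real. Compound 3 is expected to give about 6000 nM in this assay, within 1200 nM to 30000 nM.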

Compound 3, concentration for 50% growth inhibition: > 50000 nM
Compound 3 was reported as a limit; the forecaster's own chance of this, stated with the estimate: 35%; at least 8.3-fold (0.92 log units) between middle value and limit.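

Compound 2 and compound 3 both stand only as limits of the assay in this assay, and the step between them cannot be read. The compounds shown leave open whether 4-chloro-3-(trifluoromethyl)phenyl in place of 2-chloro-4-methylphenyl on a nitrogen on an aromatic ring changes inhibition of growth at all, and by how much.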